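Three Variations at One Amine Nitrogen, and a Fourth

The compounds below may be only part of what the source reports. "The series", "measured", "known", "first", "only" and "open" are said of these compounds alone.

Measured compounds in a functional assay on HeLa cells (Homo sapiens) for inhibition, read by MTT assay, with a stated time of 48 h; on this read-out higher numbers stand for weaker inhibition and lower numbers for stronger inhibition:
- Compound 1, `CCOC(=O)C1=C(N/C=N/c2ccc([N+](=O)[O-])cc2)Nc2[nH]nc(C)c2C1c1ccc(N(C)C)cc1`: compound 1 gives 57800 nM
- Compound 2, `CCOC(=O)C1=C(N/N=C(/C(=O)Br)c2ccc(Cl)cc2)Nc2[nH]nc(C)c2C1c1ccc(N(C)C)cc1`: compound 2 gives 49300 nM
- Compound 3, `CCOC(=O)C(=NNC1=C(C(=O)OCC)C(c2ccc(N(C)C)cc2)c2c(C)n[nH]c2N1)C(=O)OCC`: compound 3 gives 83800 nM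

Compound 1 stands second highest of the three numbers in this assay. Its nearest neighbour is compound 2, with a 1.2-fold lower number from compound 1 to compound 2 (0.07 log units; within the scatter); its furthest is compound 3, with a 1.4-fold higher number from compound 1 to compound 3 (0.16 log units; within the scatter). Compound 2 and compound 3 lie a 1.7-fold higher number from compound 2 to compound 3 (0.23 log units; within the scatter) apart. All three differences fall within the scatter, so the three compounds cannot be told apart on these numbers.

Compound 4, `CCOC(=O)C1=C(N/N=C(/Cl)c2ccc([N+](=O)[O-])cc2)Nc2[nH]nc(C)c2C1c1ccc(N(C)C)cc1`, has not yet been measured. It differs from compound 1 as follows: a group of 12 heavy atoms (7 carbon, 2 nitrogen, 2 oxygen, 1 chlorine; one six-membered aromatic ring of carbon only) in place of a group of 11 heavy atoms (7 carbon, 2 nitrogen, 2 oxygen; one six-membered aromatic ring of carbon only), on an amine nitrogen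

Every measured step here alters the group on the same amine nitrogen, and none of them moved the number beyond the scatter, whether the entering group kept the aromatic ring or lost it. The change to compound 4 keeps the aromatic ring and adds a chlorine, which is a smaller departure than either measured change. Compound 4 is therefore expected to stay near compound 1, with an estimated step of a 1.1-fold lower number from compound 1 to compound 4 (0.02 log units; within the scatter), that is, no change beyond the scatter. Compound 4 is estimated to give 55000 nM, within a range from 25000 nM to 120000 nM.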

Compound 4, half-maximal inhibitory concentration: 46200 nM
The estimate for compound 4 lay 1.2-fold (0.08 log units) above the measured number; the measured number falls inside the stated range.
By their numbers in this assay, from the lowest: compounds 4, 2, 1 and 3 (each within the scatter of the next).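

With compound 4, the group on the amine nitrogen whose other neighbours are a double-bonded ring carbon gains a chlorine while the aromatic ring and the counted hydrogen-bond donors and acceptors stay the same, and in this assay this gives a 1.3-fold lower number from compound 1 to compound 4 (0.10 log units; within the scatter). The two chlorine-bearing groups, which differ in the rest of their atoms, are also not separated, with a 1.1-fold lower number from compound 2 to compound 4 (0.03 log units; within the scatter), so chlorine can enter this group in either of two settings without a step beyond the scatter, though compound 3 has no chlorine and is not separated from them either. Even the pairing of this new aromatic group with the ring-free group of compound 3 gives only a 1.8-fold lower number from compound 3 to compound 4 (0.26 log units; within the scatter), which extends the flat picture at this position to a fourth group.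

Still open, on these data alone, is whether a group carrying a primary amine, a carboxylic acid or a longer alkyl chain on this nitrogen would move the number beyond the scatter, and whether changing the ethyl ester or the dimethylamino group shared by all four compounds would do so. Nothing available here accounts for why these four groups read alike.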